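This account rests on a few compounds, and the source may have more. Where it says the series, first, only, none or still open, it means among the compounds named here.

In a functional assay on PANC-1 cells (Homo sapiens) for cytotoxicity, read by resazurin assay, with a stated time of 72 h (a higher number here means a weaker inhibitor, a lower number a stronger inhibitor), compound 3 `Clc1nss/c1=N\c1cccc(Br)c1` gives 38000 nM, the lowest of the two numbers shown. Compound 2 `CSc1ccc(/N=c2\ssnc2Cl)cc1` gives 86000 nM, a number somewhat higher. Compound 1 `FC(F)(F)Oc1ccc(/N=c2\ssnc2Cl)cc1Br` gives only a limit of the assay, > 100000 nM. For the measured compounds named here, the one measured step, an at least 2.6-fold lower number from compound 1 to compound 3 (0.42 log units; beyond the scatter), changed a group on the aromatic ring; the limit of > 100000 nM in this assay, at which 1 of the 3 values shown sits, caps how large that step can be read. Compound 4 `N#Cc1c(Br)cccc1/N=c1\ssnc1Cl` differs from compound 3 by cyano in place of hydrogen on an aromatic carbon. Going by the values given here, no measured step adds a cyano group, so the direction of this change is open, and a step no larger than the scatter is expected, a 1.3-fold lower number from compound 3 to compound 4 (0.10 log units; within the scatter). Compound 4 is therefore expected to give about 30000 nM in this assay, within a range of 8000 nM to 120000 nM.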

Compound 4, half-maximal inhibitory concentration: 13000 nM
Beside the measured number, compound 4's estimate is 2.3-fold (0.36 log units) above it; low and high end bracket the measured number.
By their numbers in this assay, from the lowest: compound 4; then compound 3; then compound 2. At a limit, above all of these: compound 1.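

Putting cyano on this aromatic carbon, ortho to a bromo group, gives a 2.9-fold lower number from compound 3 to compound 4 (0.47 log units; beyond the scatter) in this assay, so this carbon can carry a group while the number still falls modestly. For the compounds shown here, the earlier step showed only a group leaving the ring; this is the first case of an added group lowering the number. Nothing measured here accounts for the size of this step.

As far as these compounds go, whether an amine, a carboxylic acid or a methyl group on this carbon would also lower the number stays open. So does the effect of cyano on other ring carbons.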